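From Chloro to Bromo at the Limit of Growth Inhibition

The source may report more compounds than this note shows. Statements on the series, on what has been measured and on what is new or still open speak of the compounds shown alone.

In a functional assay on PC-3 cells (Homo sapiens) for inhibition, read by sulforhodamine B assay, with a stated time of 48 h (a lower number here means a stronger inhibitor of growth, a higher number a weaker inhibitor of growth), compound 2 `CC(C)(C)NCc1c(C(=O)O)nn(-c2ccc(Cl)cc2)c1-c1ccc(Cl)cc1` stands at > 599000 nM, a limit of the assay and not a number. Compound 1 `CCOC(=O)c1nn(-c2ccc(Cl)cc2)c(-c2ccc(Br)cc2)c1CNC(C)(C)C` likewise gives only limits in this assay, at > 511000 nM; > 476000 nM (2 entries).

Compound 3 `CC(C)(C)NCc1c(C(=O)O)nn(-c2ccc(Cl)cc2)c1-c1ccc(Br)cc1` differs from compound 2 in one place, with bromo in place of chloro on an aromatic carbon, turning 4-chlorophenyl into 4-bromophenyl: bromo in place of chloro on an aromatic carbon. No measured step between two of these compounds shows what such a change does, so the expectation rests on the limit of compound 2 at > 599000 nM. No change beyond the scatter is expected in this assay, in either direction. The expected step of an at least 1.1-fold lower number from compound 2 to compound 3 (0.04 log units; that floor lies within the scatter) is accordingly small. For compound 3 the estimated value is 540000 nM, within an expected range of 250000 nM to 800000 nM, and the assay is likely to report only a limit again.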

Compound 3, concentration for 50% growth inhibition: > 542000 nM
Compound 3: only a limit was reported; the forecaster's own chance of this, stated with the estimate: 85%; middle value at least 1.0-fold (0.00 log units) from the limit.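

Compound 3 stands at > 542000 nM, a limit of the assay and not a number. For the compounds shown here, compound 2 also gives only a limit, > 599000 nM, so no step from compound 2 to compound 3 can be read. The compounds shown leave open how strongly, if at all, each would inhibit growth.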